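From compound 2 to compound 4: adding hydroxymethyl

The compounds below may be only part of what the source reports. "The series", "measured", "known", "first", "only" and "open" are said of these compounds alone.

In a physicochemical assay for solubility (on this read-out lower numbers stand for lower solubility and higher numbers for higher solubility), compound 1 `CNC(=O)c1cccn(Cc2ccccc2)c1=O` gives 78 ug/mL. Compound 2 `CNC(=O)c1cc(C(=O)NC)c(=O)n(Cc2ccccc2)c1` gives >= 118 ug/mL, which is a limit of the assay and not a number. Compound 3 `CNC(=O)c1ccc(=O)n(Cc2ccccc2)c1` gives >= 108 ug/mL, also a limit. Compound 4 `CNC(=O)c1cc(C(=O)NCCO)cn(Cc2ccccc2)c1=O` differs from compound 2 in one place (hydroxymethyl in place of hydrogen on a saturated chain carbon bound to an amide-type nitrogen), which turns methylcarbamoyl to (2-hydroxyethyl)carbamoyl. Within the data shown here, no measured step makes this same change. The closest evidence is the gain and loss of a whole methylcarbamoyl group, seen in an at least 1.5-fold higher number from compound 1 to compound 2 (0.17 log units; that floor lies within the scatter) and a step that the two limits leave unreadable from compound 2 to compound 3. Neither gives a readable step beyond the scatter, so none beyond the scatter is expected here, and the estimated step is a step that the limit leaves unreadable from compound 2 to compound 4. For compound 4 the estimate is 130 ug/mL, with an expected range of 70 ug/mL to 260 ug/mL.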

Compound 4, solubility: >= 140 ug/mL
Compound 4: a limit, no number; the forecaster's own chance of this, stated with the estimate: 60%; middle value at least 1.0-fold (0.03 log units) from the limit.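

In this assay compound 4 also gives a limit and not a number: the limit of >= 140 ug/mL in this assay, at which 1 of the 4 values shown sits. The change from methyl to 2-hydroxyethyl therefore cannot be sized, and neither can any other step between two limits. Among these compounds, the one step that can be read is an at least 1.7-fold higher number from compound 1 to compound 4 (0.25 log units; that floor lies within the scatter).

On these data alone, the true values of compound 2 and compound 4 remain open. So does what an amine, a carboxylic acid or a longer chain would give at this place.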